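The source may hold more compounds than are shown below. What is called first, only, known or untested is meant among the compounds shown, and "the series" means these compounds.

Measured in a physicochemical assay for solubility, read by LC-MS, using the shake flask method, measured as thermodynamic solubility, with a stated time of 24 h, at pH 6.5; on this read-out higher numbers stand for higher solubility and lower numbers for lower solubility:
- Compound 1 `OC[C@H]1O[C@H](OCc2cn(-c3cccc(F)c3)nn2)[C@@H](O)[C@@H](O)[C@@H]1O`: > 3000 ug/mL, a limit
- Compound 2 `OC[C@H]1O[C@H](n2cc(-c3ccccc3)nn2)[C@@H](O)[C@@H](O)[C@@H]1O`: > 3000 ug/mL, a limit
- Compound 3 `OC[C@H]1O[C@H](n2cc(-c3ccc(C(F)(F)F)cc3)nn2)[C@@H](O)[C@@H](O)[C@@H]1O`: 159 ug/mL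

Compound 2 gives only a limit and no exact number, and it stands at the top of these results: the limit of > 3000 ug/mL in this assay, at which 2 of the 3 values shown sit. Compound 4 `OC[C@H]1O[C@H](n2cc(COc3ccccc3)nn2)[C@@H](O)[C@@H](O)[C@@H]1O` has not yet been measured, and it differs from compound 2 by one change: phenoxymethyl in place of phenyl on an aromatic carbon. Among the measured compounds shown here, the only measured step, an at least 18-fold lower number from compound 2 to compound 3 (1.27 log units; beyond the scatter), is large, but it is a different change, trifluoromethyl in place of hydrogen, so it bears only loosely on this one. Differing from compound 2 in more than one place, compound 1 also reports only a limit, > 3000 ug/mL. A large drop is therefore not expected. The estimated change is small: a number no higher from compound 2 to compound 4 (the limit leaves the size open). For compound 4 the expected value is 3000 ug/mL, with an estimated range from 1000 ug/mL to 6000 ug/mL.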

Compound 4, solubility: > 3000 ug/mL
Compound 4: no number, only a limit; the forecaster's own chance of this, stated with the estimate: 65%; the middle value lies on the limit itself.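

Compound 2 and compound 4 each give only a limit and no exact number, so the step between them cannot be read: the limit of > 3000 ug/mL in this assay, at which 3 of the 4 values shown sit. The compounds shown leave open whether phenoxymethyl in place of phenyl changes the solubility at all, and by how much.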